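Allyl to isobutyl on a selenocyanate carbamate

This account rests on a few compounds, and the source may have more. Where it says the series, first, only, none or still open, it means among the compounds named here.

Measured compounds:
compound 1 `CC(C)COC(=O)Nc1ccc([Se][Se]c2ccc(NC(=O)OCC(C)C)cc2)cc1` — 48600 nM
compound 2 `C=CCOC(=O)Nc1ccc([Se]C#N)cc1` — 48600 nM
compound 3 `CCCCOC(=O)Nc1ccc([Se][Se]c2ccc(NC(=O)OCCCC)cc2)cc1` — 55000 nM

Of the compounds shown here, three have been tested in a functional assay on HT-29 cells (Homo sapiens) for cytotoxicity, read by MTT assay, with a stated time of 72 h; a lower number here means a stronger inhibitor of growth, a higher number a weaker inhibitor of growth. In this assay compound 1 gives 48600 nM and compound 2 gives 48600 nM, the same number at the digits shown. Compound 3 gives 55000 nM, a slightly higher figure that still lies within the scatter of the other two, so none of the three can be told apart on these numbers. Compound 2 therefore stands level with compound 1 and, within the scatter, with compound 3.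

The next compound, compound 4 `CC(C)COC(=O)Nc1ccc([Se]C#N)cc1`, keeps the core of compound 2 and changes only the carbamate chain: isopropyl in place of vinyl on a saturated chain carbon bound to an oxygen next to a carbonyl group. For the measured compounds named here, no measured pair in this set tests such a chain change alone, but compound 1 and compound 3, which differ only in chain shape, lie within the scatter of each other. Compound 4 is expected to show a 1.1-fold lower number from compound 2 to compound 4 (0.02 log units; within the scatter), that is, no change beyond the scatter. The estimated value of compound 4 is 46000 nM, with a range of 20000 nM to 100000 nM.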

Compound 4, concentration for total growth inhibition: 31300 nM
Beside the measured number, compound 4's estimate is 1.5-fold (0.17 log units) above it; measured number inside the range.
By their numbers in this assay, from the lowest: compounds 4, 1, 2 and 3 (each within the scatter of the next).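

For the compounds shown here, the swap of allyl for isobutyl gives a 1.6-fold lower number from compound 2 to compound 4 (0.19 log units; within the scatter) in this assay and, with the shared core held fixed, this is the first reading of the carbamate chain on its own. At this position, then, the two chains cannot be told apart, and neither losing the double bond nor gaining the branch produces a difference larger than repeat measurements would. Nothing on hand ties this result to any property of either chain.

Going by these compounds, only these two small chains have been compared on this core, so it remains open whether a much longer chain such as octyl, or a benzyl group, would separate from them. A chain ending in an amine or a carboxylic acid is equally untested by these compounds.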